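Swapping Nitro for Methoxy on the Shared Core

This account rests on a few compounds, and the source may have more. Where it says the series, first, only, none or still open, it means among the compounds named here.

Three compounds have been measured in a functional assay on the whole organism for inhibition, with Rattus norvegicus as the target, at a dose of 30 mg/kg; on this read-out lower numbers stand for less inhibition and higher numbers for more inhibition at the one dose given (going by the name of the read-out):

Compound 1 `Cc1ccc(-c2nc3cccnc3o2)cc1`: 0%
Compound 2 `c1ccc(-c2nc3cccnc3o2)cc1`: 55%
Compound 3 `O=[N+]([O-])c1ccc(-c2nc3cccnc3o2)cc1`: 5%

Compound 3 stands second highest of the three, with compound 1 nearest within the scatter, while compound 2 lies far off: a number 50 percentage points lower from compound 2 to compound 3 (beyond the scatter). Compound 4 `COc1ccc(-c2nc3cccnc3o2)cc1` differs from compound 3 by methoxy in place of nitro on an aromatic carbon. Among the measured compounds shown here, two measured steps bear on this: a number 55 percentage points higher from compound 1 to compound 2 (beyond the scatter) and a number 50 percentage points lower from compound 2 to compound 3 (beyond the scatter), each large, and both show that a group on the aromatic carbon, whether methyl or nitro, goes with much lower inhibition than hydrogen there. For the measured compounds named here, no step from nitro to methoxy has been measured. Since methoxy is again a group on that carbon, the expected step is small: a number 5 percentage points higher from compound 3 to compound 4 (within the scatter). Compound 4 is therefore estimated at 10%, within 0% to 40%.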

Compound 4, a percentage reported as inhibition, in the whole organism at one dose (the size of the read-out at that dose, not a potency): 29%
Compound 4: middle estimate off by 19 percentage points, on the low side; the measured number falls inside the stated range.
By their numbers in this assay, from the lowest: compounds 1 and 3 (each within the scatter of the next); then compound 4; then compound 2.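

A group on this aromatic carbon does not by itself bring the number down to the level of methyl or nitro: methoxy gives a number 24 percentage points higher from compound 3 to compound 4 (beyond the scatter) and a number 29 percentage points higher from compound 1 to compound 4 (beyond the scatter). Hydrogen still stands higher, with a number 26 percentage points lower from compound 2 to compound 4 (beyond the scatter), so the choice of group matters as well as its presence. No evidence at hand accounts for this order. On these data alone, whether an amine, a carboxylic acid or a longer chain such as ethoxy on this carbon would land nearer compound 2 or compound 1 stays open. So does whether any group there can match hydrogen.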